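The compounds below may be only part of what the source reports. "The series", "measured", "known", "first", "only" and "open" are said of these compounds alone.

The series rests on a shared core carried by three measured compounds: compound 1 `Clc1ccccc1CO/N=C/c1c(-c2ccc3ccccc3c2)nc2occn12`, compound 2 `Clc1ccc(CO/N=C/c2c(-c3ccc4ccccc4c3)nc3occn23)c(Cl)c1` and compound 3 `CC(C)c1ccc(-c2nc3sccn3c2/C=N/OCc2ccc(Cl)c(Cl)c2)cc1`. In an assay on HepG2 cells for agonist activity at nuclear receptor subfamily 1 group I member 3 (Homo sapiens), read by a luciferase reporter, with a stated time of 23 h (a higher number here means that more compound is needed for the effect, a lower number that less compound is needed), compound 1 gives 1100 nM, compound 2 gives 1500 nM, and compound 3 gives 590 nM, the lowest of the three numbers, though its gap to compound 1 lies within the scatter and only its gap to compound 2 lies beyond it. Among the measured compounds shown here, the one measured step, a 1.4-fold higher number from compound 1 to compound 2 (0.13 log units; within the scatter), concerns a chloro in place of hydrogen on an aromatic carbon.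

Compound 4 `N#Cc1ccc(-c2nc3sccn3c2/C=N/OCc2ccc(Cl)c(Cl)c2)cc1` is not yet measured. It differs from compound 3 by cyano in place of isopropyl on an aromatic carbon, on the six-membered aromatic ring of carbon only, para to a large group. For the measured compounds named here, no measured step touches this kind of change, and the step from compound 1 to compound 2 bears on a different position and group. The expectation therefore rests on compound 3 alone and is held close to it: the step in this assay from compound 3 to compound 4 is expected to be a 1.4-fold higher number from compound 3 to compound 4 (0.13 log units; within the scatter), within the scatter. For compound 4 the expected value in this assay is 800 nM, with a range from 250 nM to 2600 nM.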

Compound 4, half-maximal effective concentration: 3400 nM
Compound 4: middle estimate off by 4.3-fold (0.63 log units), on the low side; the measured number lies above the stated range.
By their numbers in this assay, from the lowest: compounds 3, 1 and 2 (each within the scatter of the next, the first and the last beyond it); then compound 4.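

In this assay, the change from 4-isopropylphenyl to 4-cyanophenyl gives a 5.8-fold higher number from compound 3 to compound 4 (0.76 log units; beyond the scatter). Unlike the one earlier step, which stayed within the scatter, this shows that the number can move beyond the scatter with a single change in the series, here on the six-membered aromatic ring of carbon only, para to a large group, where isopropyl goes with the lower number and cyano with the higher. No measurement shown here accounts for this difference between the two groups.

The compounds shown leave open how an amine, a carboxylic acid or a longer chain at this place would compare with isopropyl and cyano. They also leave open whether the same change would give a step of similar size on the core of compound 1.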